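The source may hold more compounds than are shown below. What is called first, only, known or untested is meant among the compounds shown, and "the series" means these compounds.

Among the measured compounds shown here, in a functional assay on the whole organism (strain Wistar albino) for inhibition, with Rattus norvegicus as the target, read by paw edema, with stated times of 30 min and 0.5 h, at a dose of 20 mg/kg by the oral route (on this read-out higher numbers stand for more inhibition at the one dose given (going by the name of the read-out) and lower numbers for less inhibition), compound 2 `CC(C)Cc1ccc(C(C)c2nnc3sc(-c4ccc(Br)cc4)nn23)cc1` gives 28%, the higher of the two numbers measured so far: compound 1 `CCc1nn2c(C(C)c3ccc(CC(C)C)cc3)nnc2s1` gives 5%, and the step of a number 23 percentage points higher from compound 1 to compound 2 (beyond the scatter) shows that putting 4-bromophenyl in place of ethyl raised the read-out. Compound 3 `CC(C)Cc1ccc(C(C)c2nnc3sc(-c4ccccc4Cl)nn23)cc1` differs from compound 2 by 2-chlorophenyl in place of 4-bromophenyl on an aromatic carbon. For the measured compounds named here, no measured step exchanges 4-bromophenyl for 2-chlorophenyl, so the only guide is that compound 3 keeps a phenyl ring where compound 2 has one, and no change beyond the scatter is expected a number 3 percentage points lower from compound 2 to compound 3 (within the scatter). Compound 3 is therefore estimated at 25%, within a range of 5% to 45%.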

Compound 3, a percentage reported as inhibition, in the whole organism at one dose (the size of the read-out at that dose, not a potency): 64%
The estimate for compound 3 lay 39 percentage points below the measured number; the measured number lies above the stated range.
By their numbers in this assay, from the lowest: compound 1; then compound 2; then compound 3.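

In this assay a phenyl ring at this position does not settle the outcome: 2-chlorophenyl in place of 4-bromophenyl gives a number 36 percentage points higher from compound 2 to compound 3 (beyond the scatter) even though both groups have the same count of heavy atoms and one aromatic ring each. Set against ethyl, 2-chlorophenyl gives a number 59 percentage points higher from compound 1 to compound 3 (beyond the scatter) and so shows a large step at this position. Nothing available explains why these two groups differ. The step changes both the halogen and its place on the phenyl ring, and these two changes cannot be told apart. Going by these compounds, how 4-chlorophenyl, 2-bromophenyl or a phenyl ring carrying an amine would read here remains open.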